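Series notes: methyl to ethyl on compound 2

This account rests on a few compounds, and the source may have more. Where it says the series, first, only, none or still open, it means among the compounds named here.

Measured compounds:
compound 1, `Nc1ccccc1NC(=O)/C=C/c1ccc(CSc2ccc(F)cc2)cc1`: "not determined" (no result reported)
compound 2, `Cc1ccc(SCc2ccc(C(=O)Nc3ccccc3N)cc2)cc1`: 2630 nM
compound 3, `Nc1ccccc1NC(=O)/C=C/c1ccc(CSc2cccc3ccccc23)cc1`: "not determined" (no result reported)

Among the compounds with values here, in a functional assay on HCT-116 cells (Homo sapiens) for antiproliferative activity, read by CCK-8 assay, with a stated time of 72 h (on this read-out higher numbers stand for weaker inhibition and lower numbers for stronger inhibition), compound 2 gives 2630 nM, which is the only number in the set; compound 1 and compound 3 carry no result there. Compound 4, `CCc1ccc(SCc2ccc(C(=O)Nc3ccccc3N)cc2)cc1`, differs from compound 2 by one change: methyl in place of hydrogen on a saturated chain carbon bound to an aromatic carbon. Read one bond further out, the same difference is methyl to ethyl, 4-methylphenyl to 4-ethylphenyl. Within the data shown here, no pair of measured compounds shows what such a change does in this assay, so the step from compound 2 is expected to stay within the usual scatter, in no particular direction. Compound 4 is therefore expected to give 2500 nM, between 1100 nM and 5600 nM. The step of a 1.1-fold lower number from compound 2 to compound 4 (0.02 log units; within the scatter) is the size expected for this change.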

Compound 4, half-maximal inhibitory concentration: 1740 nM
Beside the measured number, compound 4's estimate is 1.4-fold (0.16 log units) above it; low and high end bracket the measured number.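

In this assay, within the data shown here, the change from methyl to ethyl gives a 1.5-fold lower number from compound 2 to compound 4 (0.18 log units; within the scatter) and so provides the first measured step at this position. Among these compounds, on this single pair, the added methyl on a saturated chain carbon bound to an aromatic carbon stays within the scatter, which no earlier pair could show. No measurement shown bears on the reason for this result.

Still open, going by these compounds, is how a longer chain such as propyl, an amine or a carboxylic acid would read at this position. On these data alone, whether the step holds on the core of compound 1 also remains open.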